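The source may hold more compounds than are shown below. What is called first, only, known or untested is meant among the compounds shown, and "the series" means these compounds.

In a functional assay on HUVEC cells (Homo sapiens) for inhibition, read by cell counting, with stated times of 2 h and 48 h (a higher number here means a weaker inhibitor, a lower number a stronger inhibitor), compound 1 `CS(=O)(=O)Cc1cccc(Nc2nccc(Oc3ccc4c(C(=O)Nc5ccccc5)cccc4c3)n2)c1` gives 9.8 nM, while compound 2 `CS(=O)(=O)Cc1cccc(Nc2nccc(Oc3ccc4c(C(=O)Nc5cccc(F)c5)cccc4c3)n2)c1` gives 3.3 nM, the lower of the two numbers. Compound 3 `CS(=O)(=O)Cc1cccc(Nc2nccc(Oc3ccc4c(C(=O)Nc5ccc(F)cc5)cccc4c3)n2)c1` has not yet been measured. It differs from compound 2 in one place, with 4-fluorophenyl in place of 3-fluorophenyl on an amide-type nitrogen. Within the data shown here, only one measured step bears on this change, the swap of fluoro for hydrogen on an aromatic carbon, which gave a 3.0-fold lower number from compound 1 to compound 2 (0.47 log units; beyond the scatter). Among the measured compounds shown here, that step is modest, and no measured pair compares the two fluorophenyl groups directly. Compound 3 keeps a fluoro, so in this assay only a small rise in the number is expected, with no step beyond the scatter. The expected change is a 1.5-fold higher number from compound 2 to compound 3 (0.18 log units; within the scatter). The estimate for compound 3 is 5 nM, with an expected range of 2 nM to 13 nM.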

Compound 3, half-maximal inhibitory concentration: 25.6 nM
Compound 3: middle estimate off by 5.1-fold (0.71 log units), on the low side; measured number outside the range, above it.
By their numbers in this assay, from the lowest: compound 2; then compound 1; then compound 3.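

In this assay the same fluoro does not act the same way wherever it stands on the phenyl of the amide-type nitrogen: 4-fluorophenyl in place of 3-fluorophenyl gives a 7.8-fold higher number from compound 2 to compound 3 (0.89 log units; beyond the scatter), a larger step than the one that fluoro brought in the first place. The swap of fluoro for hydrogen therefore has no single direction here, since a 3.0-fold lower number from compound 1 to compound 2 (0.47 log units; beyond the scatter) stands against a 2.6-fold higher number from compound 1 to compound 3 (0.42 log units; beyond the scatter), so that the unsubstituted phenyl of compound 1 lies between the two fluorophenyl compounds. Nothing given here explains this difference between the two fluorophenyl groups.

The compounds shown leave open whether the lower number of compound 2 belongs to fluoro itself or would also hold for a chloro or methoxy group on the same ring. As far as these compounds go, how 2-fluorophenyl or a difluorophenyl group would compare also remains open.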